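The compounds below may be only part of what the source reports. "The series", "measured", "known", "first", "only" and "open" are said of these compounds alone.

Series of chloromethyl ketones sharing one core and differing only in the length of the saturated chain attached to the sulfur. Compound 1 `CCCCCCCCCCCSC[C@H](NC(C)=O)C(=O)CCl` is the reference; in a functional assay on NALM-6 cells (Homo sapiens) (a lower number here means a stronger inhibitor, a higher number a weaker inhibitor), compound 1 gives 1700 nM. Compound 2 `CCCCCCCCCCCCCSC[C@H](NC(C)=O)C(=O)CCl` reaches only the edge of this assay: for compound 2 the result is > 100000 nM, a limit of the assay and not a number (the limit of > 100000 nM in this assay, at which 1 of the 3 values shown sits). Compound 3 `CCCCCCCCCCCCCCCCSC[C@H](NC(C)=O)C(=O)CCl` in this assay gives 16000 nM, the higher of the two numbers; its nearest neighbour is compound 1, the step being a 9.4-fold higher number from compound 1 to compound 3 (0.97 log units; beyond the scatter). The remaining steps are an at least 58-fold higher number from compound 1 to compound 2 (1.76 log units; beyond the scatter) and an at least 6.2-fold lower number from compound 2 to compound 3 (0.79 log units; beyond the scatter), so the chain lengthening does not run as a smooth trend, compound 2 lying outside the order set by compound 1 and compound 3.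

Compound 4 `CCCCCCCCCCCCCCCCCCCCSC[C@H](NC(C)=O)C(=O)CCl` carries the change (butyl in place of hydrogen on a saturated chain carbon, ten or more bonds along the chain from a sulfur). The steps bearing on it are a 9.4-fold higher number from compound 1 to compound 3 (0.97 log units; beyond the scatter), an at least 58-fold higher number from compound 1 to compound 2 (1.76 log units; beyond the scatter) and an at least 6.2-fold lower number from compound 2 to compound 3 (0.79 log units; beyond the scatter), all beyond the scatter and all extending the same chain. Each extension starting from compound 1 has raised the number, though an at least 6.2-fold lower number from compound 2 to compound 3 (0.79 log units; beyond the scatter) runs the other way; a further modest rise in this assay is therefore expected for compound 4, a 2.5-fold higher number from compound 3 to compound 4 (0.40 log units; beyond the scatter), with a real chance that only a limit is returned. The estimate for compound 4 in this assay is 40000 nM, expected to fall between 8000 nM and 200000 nM.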

Compound 4, half-maximal inhibitory concentration: > 100000 nM
Compound 4 ended at the assay's limit; the forecaster's own chance of this, stated with the estimate: 35%; at least 2.5-fold (0.39 log units) between middle value and limit.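

In this assay the result for compound 4 is a limit of the assay and not a number, the same limit that compound 2 reached: the limit of > 100000 nM in this assay, at which 2 of the 4 values shown sit.

Adding butyl to the chain of compound 3 gives an at least 6.2-fold higher number from compound 3 to compound 4 (0.79 log units; beyond the scatter), and the full extension from the reference gives an at least 58-fold higher number from compound 1 to compound 4 (1.76 log units; beyond the scatter), so the lower number at compound 3 does not carry on to the longest chain shown and compound 1 stays the strongest inhibitor of the four. Within the data shown here, a rise with chain length now fits compound 1, compound 3 and compound 4, with compound 2 the one compound against it, and the step from compound 2 to compound 4 cannot be read, since both ends of it are limits.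

On these data alone, how far compound 4 lies past the limit stays open, and so does whether the out-of-order result of compound 2 belongs to that chain length alone or would recur in neighbouring chains. Also open, as far as these compounds go, is whether a chain shorter than that of compound 1, or an amine or a carboxylic acid at the far end of a long chain, would bring the number back down in this assay.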